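Estimating Compound 4 from Three Measured Partition Coefficients

The compounds below may be only part of what the source reports. "The series", "measured", "known", "first", "only" and "open" are said of these compounds alone.

Measured compounds:
- compound 1, `CN(CCC#N)C[C@H]1CN(c2ccc(-n3cc(-c4ccccn4)cn3)c(F)c2)C(=O)O1`: 1.9
- compound 2, `CN1CCN(C[C@H]2CN(c3ccc(-n4cc(-c5ccccn5)cn4)c(F)c3)C(=O)O2)CC1`: 2.2
- compound 3, `COC(=O)CC1CCN(C[C@H]2CN(c3ccc(-n4cc(-c5ccccn5)cn4)c(F)c3)C(=O)O2)CC1`: 1.78

The three compounds share one core and differ only in the amine attached to the saturated chain carbon. In a physicochemical assay for lipophilicity, read by HPLC, measured as octanol-water partition (on this read-out lower numbers stand for lower lipophilicity and higher numbers for higher lipophilicity), compound 3 gives the lowest of the three numbers. Its nearest neighbour is compound 1, and the two lie within the scatter of each other, as a number 0.12 log units lower from compound 1 to compound 3 (within the scatter) shows. Compound 2 stands furthest away, and a number 0.42 log units lower from compound 2 to compound 3 (beyond the scatter) is beyond the scatter.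

Compound 4, `O=C1O[C@@H](CN2CCC(c3ccc(F)cc3)CC2)CN1c1ccc(-n2cc(-c3ccccn3)cn2)c(F)c1`, is not yet measured. It keeps the six-membered ring of compound 3 and changes only what that ring carries: 4-fluorophenyl in place of (methoxycarbonyl)methyl on a saturated ring carbon. Among the compounds with values here, none of the measured steps makes this kind of change; each of them swaps one whole amine for another, and the largest of them, a number 0.42 log units lower from compound 2 to compound 3 (beyond the scatter), was modest. A replacement of a chain carrying two acceptors by an aromatic ring carrying none is a different and larger change than any seen here, so the measured steps set no firm bound. Compound 4 is therefore expected to move upward by a number 1.32 log units higher from compound 3 to compound 4 (beyond the scatter), to an estimated 3.1, with a range from 2.4 to 3.8 in this assay.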

Compound 4, partition coefficient: 5.78
The estimate for compound 4 lay 2.68 log units below the measured number; measured number outside the range, above it.
By their numbers in this assay, from the lowest: compounds 3, 1 and 2 (each within the scatter of the next, the first and the last beyond it); then compound 4.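

At this place, on a saturated ring carbon three ring bonds from the ring nitrogen, the swap of (methoxycarbonyl)methyl for 4-fluorophenyl gives a number 4.00 log units higher from compound 3 to compound 4 (beyond the scatter) in this assay. Within the data shown here, that large step shows that a change confined to one substituent on the six-membered ring can move the read-out much further than any of the whole-amine swaps among the earlier compounds, whose largest was a number 0.42 log units lower from compound 2 to compound 3 (beyond the scatter) and was modest. The data give no explanation for the size of this step.

The single step changes several things at once: a group with no ring and 2 hydrogen-bond acceptors leaves, and an aromatic ring of carbon carrying a fluorine enters, so the compounds shown leave open how much of the rise belongs to the ring, the fluorine or the loss of the ester. From the compounds shown here alone, a plain phenyl, a cyclohexyl, a carboxylic acid or a longer chain ending in a methyl ester at the same ring carbon would each bear on that question, and how far the read-out would then move remains open.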